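A few compounds are considered here, and "the series" means these few. Any claim that something is new, unique, unknown or untested is made for them only; others in the source may bear on it.

Working notes on the series, single-concentration cytotoxicity.

Three compounds share one core and differ only in the chain on the triazole. Compound 1 `CCCCCCCc1cn(C(c2ccccc2)c2cc3cc(Br)ccc3nc2OC)nn1` carries a heptyl chain, compound 2 `CCCCCCCCc1cn(C(c2ccccc2)c2cc3cc(Br)ccc3nc2OC)nn1` an octyl chain, and compound 3 `COc1nc2ccc(Br)cc2cc1C(c1ccccc1)n1cc(CCCO)nn1` a 3-hydroxypropyl chain. In an ADME assay on PANC-1 cells (Homo sapiens) for cytotoxicity, read by sulforhodamine B assay, with a stated time of 48 h, tested at 10 uM (on this read-out higher numbers stand for more inhibition at the one concentration tested (going by the name of the read-out) and lower numbers for less inhibition), compound 1 gives 16.6%, compound 2 gives 12.1%, and compound 3 gives 25.5%. Among the measured compounds shown here, compound 3 stands highest of the three numbers, but only the step of a number 13.4 percentage points higher from compound 2 to compound 3 (beyond the scatter) lies beyond the scatter, while a number 8.9 percentage points higher from compound 1 to compound 3 (within the scatter) does not, so the number for compound 3 can only be called higher than that of compound 2, not higher than that of compound 1.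

The next compound, compound 4 `COc1nc2ccc(Br)cc2cc1C(c1ccccc1)n1cc(CCO)nn1`, shortens the chain by one carbon: hydroxy in place of hydroxymethyl on a saturated chain carbon, two bonds along the chain from an aromatic carbon. For the measured compounds named here, the one measured step that changes chain length alone, a number 4.5 percentage points lower from compound 1 to compound 2 (within the scatter), stayed within the scatter. The two steps that brought in the hydroxy group, a number 8.9 percentage points higher from compound 1 to compound 3 (within the scatter) and a number 13.4 percentage points higher from compound 2 to compound 3 (beyond the scatter), both removed several chain carbons at once, so they do not separate chain length from the hydroxy. Taking the lengthening step as the closest precedent, no step beyond the scatter is expected for compound 4 in this assay, and the expected step is a number 2.5 percentage points lower from compound 3 to compound 4 (within the scatter). Compound 4 is estimated at 23%, with a range from 10% to 36%.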

Compound 4, a percentage reported as inhibition, at one concentration (the size of the read-out at that concentration, not a potency): 19.8%
The estimate for compound 4 lay 3.2 percentage points above the measured number; low and high end bracket the measured number.
By their numbers in this assay, from the lowest: compounds 2, 1, 4 and 3 (each within the scatter of the next, the first and the last beyond it).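

Shortening 3-hydroxypropyl to 2-hydroxyethyl gives a step within the scatter in this assay, a number 5.7 percentage points lower from compound 3 to compound 4 (within the scatter), so at this place, two bonds along the chain from an aromatic carbon, a one-carbon change in length stays within the scatter on a hydroxy-bearing chain as it did on the alkyl chains. Among the compounds shown here, the shorter hydroxy chain also stays within the scatter of both alkyl chains, a number 7.7 percentage points higher from compound 2 to compound 4 (within the scatter) and a number 3.2 percentage points higher from compound 1 to compound 4 (within the scatter), so the only step beyond the scatter among the alkyl-to-hydroxy changes remains the one that ends at the 3-hydroxypropyl chain. The two matched alkyl-to-hydroxy steps differ in printed size, yet that gap cannot be read as a real difference between them: the same change on two cores in this assay, a number 13.4 percentage points higher (beyond the scatter) from compound 2 to compound 3 and a number 3.2 percentage points higher (within the scatter) from compound 1 to compound 4, 10.2 percentage points apart, within the scatter of two such steps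

The compounds shown leave open whether an amine or a carboxylic acid in place of the hydroxy would give a step beyond the scatter from compound 3. They also leave open whether a hydroxymethyl chain, or a hydroxy group on a chain longer than 3-hydroxypropyl, would do so.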